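Hydroxy to Nitro on the Aromatic Ring: Compound 3 to Compound 4

This account rests on a few compounds, and the source may have more. Where it says the series, first, only, none or still open, it means among the compounds named here.

Compound 1 `COc1ccc([C@H](O)[C@H]2CO[C@@H](c3ccc(OC)c(OC)c3)[C@H](C/C=C/c3ccccc3)C2)cc1OC` gives 16100 nM in a functional assay on HeLa cells (Homo sapiens) for cytotoxicity, read by WST assay, with a stated time of 48 h; a higher number here means a weaker inhibitor, a lower number a stronger inhibitor.
Compound 2 `COc1ccc(CCC[C@H]2C[C@@H]([C@@H](O)c3ccc(OC)c(OC)c3)CO[C@@H]2c2ccc(OC)c(OC)c2)cc1OC` gives 37700 nM in this assay.
Compound 3 `Oc1ccc(/C=C/C[C@H]2C[C@@H]([C@@H](O)c3ccccc3)CO[C@@H]2c2ccccc2)cc1` gives 14400 nM in this assay.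

Compound 3 carries the lowest of these three numbers, yet its gap to compound 1 lies within the scatter, so those two cannot be ranked against each other; only compound 2 stands beyond the scatter from it. Compound 4 `O=[N+]([O-])c1ccc(/C=C/C[C@H]2C[C@@H]([C@@H](O)c3ccccc3)CO[C@@H]2c2ccccc2)cc1` differs from compound 3 in one place: nitro in place of hydroxy on an aromatic carbon. Among the measured compounds shown here, no measured pair shows this kind of change, so its effect in this assay is unknown from the data at hand. With nothing to anchor a direction, the expected step of a 1.0-fold higher number from compound 3 to compound 4 (0.02 log units; within the scatter) is set at none beyond the scatter. Compound 4 is therefore expected to give 15000 nM, within a range from 5000 nM to 45000 nM.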

Compound 4, half-maximal inhibitory concentration: 12400 nM
Beside the measured number, compound 4's estimate is 1.2-fold (0.08 log units) above it, within the range that was stated.
By their numbers in this assay, from the lowest: compounds 4, 3 and 1 (each within the scatter of the next); then compound 2.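

Putting nitro in place of hydroxy, the change from 4-hydroxyphenyl to 4-nitrophenyl, gives a 1.2-fold lower number from compound 3 to compound 4 (0.06 log units; within the scatter) in this assay and so produces no readable shift. This position therefore tolerates the swap in this read-out, even though compound 4 has no hydrogen-bond donor on this ring and a larger group stands there. Nothing available explains why the two compounds read alike.

As far as these compounds go, whether an amine or a carboxylic acid on this same aromatic carbon would also leave the number in place remains open. A single swap at this position cannot show a trend across groups.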